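Halogen variation on the N-aryl group of the shared core

This account rests on a few compounds, and the source may have more. Where it says the series, first, only, none or still open, it means among the compounds named here.

Compound 1 `O=C(Nc1ccc(Oc2ccnc3[nH]ccc23)cc1)c1cn(-c2ccc(F)cc2)c2ccccc2c1=O`: 450 nM
Compound 2 `O=C(Nc1ccc(Oc2ccnc3[nH]ccc23)cc1)c1cn(-c2ccc(Br)cc2)c2ccccc2c1=O`: 220 nM

Both compounds were run in a functional assay on HepG2 cells (Homo sapiens) for inhibition, read by MTT assay, with a stated time of 72 h; a lower number here means a stronger inhibitor, a higher number a weaker inhibitor. For the measured compounds named here, compound 2 gives the lowest number of the two; the only neighbour is compound 1, a step of a 2.0-fold lower number from compound 1 to compound 2 (0.31 log units; beyond the scatter). Compound 3 `O=C(Nc1ccc(Oc2ccnc3[nH]ccc23)cc1)c1cn(-c2ccc(F)c(Cl)c2)c2ccccc2c1=O` has not been measured. It differs from compound 2 by 3-chloro-4-fluorophenyl in place of 4-bromophenyl on an aromatic nitrogen. Going by the values given here, the single measured step bears on it only indirectly, as it also exchanges one halogen for another on the same ring and was modest. A step of about the same size or smaller, in either direction, is expected, so a 1.1-fold higher number from compound 2 to compound 3 (0.06 log units; within the scatter) is the estimate. Compound 3 is therefore expected near 250 nM, within 100 nM to 600 nM.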

Compound 3, half-maximal inhibitory concentration: 1120 nM
Beside the measured number, compound 3's estimate is 4.5-fold (0.65 log units) below it; the measured number lies above the stated range.
By their numbers in this assay, from the lowest: compound 2; then compound 1; then compound 3.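

For the compounds shown here, a second halogen on the ring at this aromatic nitrogen raises the number in both comparisons open to it, which the single halogen exchange could not show. In this assay chloro in place of hydrogen gives a 2.5-fold higher number from compound 1 to compound 3 (0.40 log units; beyond the scatter) on the fluorinated ring, while 3-chloro-4-fluorophenyl in place of 4-bromophenyl gives a 5.1-fold higher number from compound 2 to compound 3 (0.71 log units; beyond the scatter) as the widest step among these compounds. No measurement at hand bears on the reason for either rise.

From the compounds shown here alone, whether a lone chloro on this ring would sit nearer compound 2 or compound 3 stays open. So does the outcome of a methoxy group or an amine at the same place.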